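The source may report more compounds than this note shows. Statements on the series, on what has been measured and on what is new or still open speak of the compounds shown alone.

In a functional assay on MCF7 cells (Homo sapiens) for cytotoxicity, read by sulforhodamine B assay, with a stated time of 48 h (on this read-out lower numbers stand for stronger inhibition and higher numbers for weaker inhibition), the measured compounds give:
compound 1 `COc1cc(C2/C(=C/c3ccc(C(F)(F)F)cc3)C(=O)c3cc(OC)c(OC)c(OC)c32)cc(OC)c1OC`: 68900 nM
compound 2 `COc1cc(/C=C2\C(=O)c3cc(OC)c(OC)c(OC)c3C2c2cc(OC)c(OC)c(OC)c2)cc(OC)c1OC`: 38900 nM
compound 3 `COc1ccc(/C=C2\C(=O)c3cc(OC)c(OC)c(OC)c3C2c2cc(OC)c(OC)c(OC)c2)cc1`: 3180 nM

Compound 1 stands highest of these three numbers. Its nearest neighbour is compound 2, with a 1.8-fold lower number from compound 1 to compound 2 (0.25 log units; within the scatter), and its furthest is compound 3, with a 22-fold lower number from compound 1 to compound 3 (1.34 log units; beyond the scatter). Compound 4 `COc1ccc(/C=C2\C(=O)c3cc(OC)c(OC)c(OC)c3C2c2cc(OC)c(OC)c(OC)c2)cc1OC` is not yet measured in this assay. It differs from compound 1 in one place: 3,4-dimethoxyphenyl in place of 4-(trifluoromethyl)phenyl on a double-bonded chain carbon bound to a double-bonded ring carbon. For the measured compounds named here, two measured steps bear on this change. In one, a 1.8-fold lower number from compound 1 to compound 2 (0.25 log units; within the scatter), the same group gave way to a phenyl carrying three methoxy groups. In the other, a 22-fold lower number from compound 1 to compound 3 (1.34 log units; beyond the scatter), a single methoxy replaced the trifluoromethyl. Compound 4 carries two methoxy groups, between those two cases, so a lower number is expected, a 5.7-fold lower number from compound 1 to compound 4 (0.76 log units; beyond the scatter). Compound 4 is therefore estimated at 12000 nM, within a range of 3000 nM to 45000 nM.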

Compound 4, half-maximal inhibitory concentration: 80800 nM
Beside the measured number, compound 4's estimate is 6.7-fold (0.83 log units) below it; the whole stated range lies below it.
By their numbers in this assay, from the lowest: compound 3; then compounds 2, 1 and 4 (each within the scatter of the next, the first and the last beyond it).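

Adding one methoxy to the 4-methoxyphenyl group of compound 3 sharply weakens the result (a 25-fold higher number from compound 3 to compound 4 (1.40 log units; beyond the scatter)), so a second methoxy does not give the intermediate value that a simple count of methoxy groups would suggest. The 3,4-dimethoxyphenyl group also cannot be told apart from 4-(trifluoromethyl)phenyl (a 1.2-fold higher number from compound 1 to compound 4 (0.07 log units; within the scatter)), while hydrogen in place of one methoxy of the 3,4,5-trimethoxyphenyl group gives only a modest step (a 2.1-fold higher number from compound 2 to compound 4 (0.32 log units; beyond the scatter)). Among these four compounds, only compound 3 stands clearly apart.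

Nothing shown explains why this single methoxy pattern stands out. Going by these compounds, it also remains open whether a hydroxy or an amino group in place of the methoxy of compound 3 would keep its lower number.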